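Aryl exchange on the shared core: a further halogenated phenyl

This account rests on a few compounds, and the source may have more. Where it says the series, first, only, none or still open, it means among the compounds named here.

Three compounds on the same core differ only in the aryl group carried on a nitrogen on an aromatic ring. Compound 1 `CN1CCN(CCCOc2cccc3nc(Nc4ccc(Cl)c(C(F)(F)F)c4)ccc23)CC1` gives 1470 nM in a functional assay on MDA-MB-231 cells (Homo sapiens) for inhibition, read by sulforhodamine B assay, with a stated time of 48 h; on this read-out higher numbers stand for weaker inhibition of growth and lower numbers for stronger inhibition of growth; compound 2 `CC(C)c1ccc(Nc2ccc3c(OCCCN4CCN(C)CC4)cccc3n2)cc1` gives 2110 nM in this assay; compound 3 `CN1CCN(CCCOc2cccc3nc(Nc4ccc(F)c(F)c4)ccc23)CC1` gives 937 nM in this assay. Among the compounds with values here, compound 3 sits at the low end of the three numbers, yet the step of a 1.6-fold lower number from compound 1 to compound 3 (0.20 log units; within the scatter) is within the scatter, so compound 3 and compound 1 cannot be told apart; only the step of a 2.3-fold lower number from compound 2 to compound 3 (0.35 log units; beyond the scatter) lies beyond the scatter, and then modestly. The remaining pairing, a 1.4-fold higher number from compound 1 to compound 2 (0.16 log units; within the scatter), is also within the scatter.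

Compound 4 `CN1CCN(CCCOc2cccc3nc(Nc4cc(Cl)cc(Cl)c4)ccc23)CC1` is not yet measured. Relative to compound 3 the change is 3,5-dichlorophenyl in place of 3,4-difluorophenyl on a nitrogen on an aromatic ring, one more exchange of the aryl group at the same place. The three measured exchanges at this place all gave small steps in this assay, two within the scatter and one modestly beyond it, with no consistent direction. Another such exchange is therefore expected to move this assay little. The expected step is a 1.3-fold higher number from compound 3 to compound 4 (0.11 log units; within the scatter), within the scatter. For compound 4 the estimated value is 1200 nM, with a range from 500 nM to 3000 nM.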

Compound 4, concentration for 50% growth inhibition: 1570 nM
Compound 4: the middle estimate sits 1.3-fold (0.12 log units) below what was measured; the measured number falls inside the stated range.
By their numbers in this assay, from the lowest: compounds 3, 1, 4 and 2 (each within the scatter of the next, the first and the last beyond it).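

Compound 4 brings two changes at once, chlorine for fluorine and a new substitution pattern on the phenyl ring, and the step stays within the scatter in this assay (a 1.7-fold higher number from compound 3 to compound 4 (0.22 log units; within the scatter)). Within the data shown here, its steps from the other two aryl groups also stay within the scatter (a 1.3-fold lower number from compound 2 to compound 4 (0.13 log units; within the scatter); a 1.1-fold higher number from compound 1 to compound 4 (0.03 log units; within the scatter)), so compound 4 cannot be told apart from any of the earlier compounds. Among these compounds, the new compound therefore adds no second separated pair to the one between compound 2 and compound 3, and across these four phenyl groups on a nitrogen on an aromatic ring the number shows little dependence on the substitution pattern; no measurement at hand explains the small differences that remain.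

All four aryl groups shown are phenyl rings carrying halogen, trifluoromethyl or isopropyl, so it remains open whether a phenyl bearing a carboxylic acid or an amine, a pyridine ring or a saturated cyclohexyl group would move the number further. From the compounds shown here alone, the effect of changing anything away from this nitrogen, such as a longer chain on the ether oxygen, also remains open.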